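The compounds below may be only part of what the source reports. "The series", "measured", "known", "first", "only" and "open" are said of these compounds alone.

Compound 1 `CCOC(=O)c1c(N/N=C2\C(=O)NN=C2C)sc2c1CCCCC2` has the highest number of the two measured compounds: in a functional assay on HT-29 cells (Homo sapiens) for inhibition, read by MTT assay, with a stated time of 48 h (on this read-out lower numbers stand for stronger inhibition and higher numbers for weaker inhibition), compound 1 gives 88100 nM. Compound 2 `CCOC(=O)/C(=N/Nc1sc2c(c1C(=O)OCC)CCCCC2)C(C)=O` stands far apart, as in this assay compound 2 gives 4500 nM, a gap beyond the scatter. Compound 3 `CCOC(=O)c1c(NN=C(C#N)C#N)sc2c1CCCCC2` differs from compound 1 by a group of 6 heavy atoms (3 carbon, 3 nitrogen; no ring) in place of a group of 8 heavy atoms (4 carbon, 3 nitrogen, 1 oxygen; one five-membered non-aromatic ring with 2 hetero atoms), on a nitrogen on an aromatic ring. Among the compounds with values here, no measured pair shows this change, so any expectation rests on the two numbers alone. The account expects compound 3 to move moderately toward stronger inhibition, with an expected step of a 4.4-fold lower number from compound 1 to compound 3 (0.64 log units; beyond the scatter). Compound 3 is therefore estimated at 20000 nM, in a range from 4000 nM to 100000 nM.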

Compound 3, half-maximal inhibitory concentration: 7600 nM
Compound 3: middle estimate off by 2.6-fold (0.42 log units), on the high side; the measured number falls inside the stated range.
By their numbers in this assay, from the lowest: compounds 2 and 3 (each within the scatter of the next); then compound 1.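

At the nitrogen on an aromatic ring, a group of 6 heavy atoms (3 carbon, 3 nitrogen; no ring) replacing the ring-bearing group of compound 1 gives a 12-fold lower number from compound 1 to compound 3 (1.06 log units; beyond the scatter) in this assay. This shows that inhibition at this position responds strongly to the group it carries, and that the five-membered non-aromatic ring is not required for the stronger value. Nothing available accounts for this step. On these data alone, it remains open whether both nitrile groups matter, or whether a carboxylic acid or an amine in place of one nitrile would keep this level of inhibition.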